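A few compounds are considered here, and "the series" means these few. Any claim that something is new, unique, unknown or untested is made for them only; others in the source may bear on it.

Measured so far in a functional assay on BGC-823 cells (Homo sapiens) for inhibition, read by MTT assay, with a stated time of 72 h; a lower number here means a stronger inhibitor, a higher number a weaker inhibitor:

compound 1, `Cc1cc(N2CC[C@@H](C)[C@@H](N(C)c3ncnc4[nH]ccc34)C2)n2nc(SCc3ccccc3)nc2n1`: 14400 nM
compound 2, `Cc1cc(N2CC[C@@H](C)[C@@H](N(C)c3ncnc4[nH]ccc34)C2)n2nc(SCC3CC3)nc2n1`: 36500 nM
compound 3, `C=CCSc1nc2nc(C)cc(N3CC[C@@H](C)[C@@H](N(C)c4ncnc5[nH]ccc45)C3)n2n1`: 40900 nM

Compound 2 gives the second highest of the three numbers. Its value and that of compound 3 lie within the scatter of each other, the step of a 1.1-fold higher number from compound 2 to compound 3 (0.05 log units; within the scatter) being no more than noise, while compound 1 sits lower, the step of a 2.5-fold higher number from compound 1 to compound 2 (0.40 log units; beyond the scatter) being beyond the scatter.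

Compound 4, `Cc1cc(N2CC[C@@H](C)[C@@H](N(C)c3ncnc4[nH]ccc34)C2)n2nc(SCc3cc(Cl)ccc3Cl)nc2n1`, is not yet measured. Its difference from compound 2:

2,5-dichlorophenyl in place of cyclopropyl on a saturated chain carbon bound to a sulfur

Of the measured steps, a 2.5-fold higher number from compound 1 to compound 2 (0.40 log units; beyond the scatter) is the one that bears on this change, since it exchanges the same aromatic ring for cyclopropyl at the same place; read backward, it points to a lower number when an aromatic ring returns. a 2.8-fold higher number from compound 1 to compound 3 (0.45 log units; beyond the scatter) and a 1.1-fold higher number from compound 2 to compound 3 (0.05 log units; within the scatter) concern vinyl and say nothing about a benzyl bearing chlorine. Among the measured compounds shown here, no measured compound carries chlorine on that ring, so its own contribution is unknown. A step in the lowering direction, of roughly the size seen between compound 1 and compound 2, is therefore expected: a 4.1-fold lower number from compound 2 to compound 4 (0.61 log units; beyond the scatter). For compound 4 the estimated value is 9000 nM, with a range from 3000 nM to 27000 nM.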

Compound 4, half-maximal inhibitory concentration: 18900 nM
The estimate for compound 4 lay 2.1-fold (0.32 log units) below the measured number, within the range that was stated.
By their numbers in this assay, from the lowest: compounds 1, 4, 2 and 3 (each within the scatter of the next, the first and the last beyond it).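

In this assay, 2,5-dichlorophenyl on a saturated chain carbon bound to a sulfur cannot be separated from phenyl (a 1.3-fold higher number from compound 1 to compound 4 (0.12 log units; within the scatter)), so the two chlorines produce no readable difference in this pair. Cyclopropyl, which was separated from phenyl, cannot be separated from 2,5-dichlorophenyl (a 1.9-fold lower number from compound 2 to compound 4 (0.29 log units; within the scatter)), whereas the change from vinyl does pass the scatter, though only modestly (a 2.2-fold lower number from compound 3 to compound 4 (0.34 log units; beyond the scatter)). No supporting data are available to account for these steps.

Going by these compounds, whether an amine, a carboxylic acid or a longer chain at this place would move the number well outside the range of these four compounds remains open. Also unsettled is whether a single chlorine on the ring would read differently from the pair in 2,5-dichlorophenyl.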